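The compounds below may be only part of what the source reports. "The series", "measured", "known", "first", "only" and "open" are said of these compounds alone.

In a functional assay on HCT-116 cells (Homo sapiens) for cytotoxicity, read by MTT assay, with a stated time of 72 h (on this read-out higher numbers stand for weaker inhibition and lower numbers for stronger inhibition), compound 1 `N[C@H]1CC[C@H](Nc2c(C(=O)NCc3ccc(F)cc3)nc(N3CCCCC3)c3cccnc23)CC1` gives 8000 nM. Compound 2 `O=C(NCc1ccc(F)cc1)c1nc(Br)c2cccnc2c1NCc1ccccc1` reaches only the limit of the assay in this assay, > 20000 nM, so no single number stands for it. For compound 3 `C[C@@H](CO)Nc1nc(C(=O)NCc2ccc(F)cc2)c(O)c2ncccc12` the entry in this assay reads "not determined" (no result reported). Compound 4 `Nc1ccc(Nc2c(C(=O)NCc3ccc(F)cc3)nc(Br)c3cccnc23)cc1` has not yet been tested; it differs from compound 2 by 4-aminophenyl in place of benzyl on a nitrogen on an aromatic ring. Compound 2 thus stands at the limit of > 20000 nM in this assay, at which 1 of the 3 values shown sits, and the step to compound 4 cannot be read from measured pairs. The replacement is expected to move the result toward stronger inhibition, by a step around or only slightly beyond the usual scatter, an at least 1.3-fold lower number from compound 2 to compound 4 (0.12 log units; that floor lies within the scatter). For compound 4 the estimate in this assay is 15000 nM, within a range from 4000 nM to 40000 nM.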

Compound 4, half-maximal inhibitory concentration: 10000 nM
Compound 4: middle estimate off by 1.5-fold (0.18 log units), on the high side, and the stated range covers the measured number.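

Placing 4-aminophenyl in place of benzyl on this nitrogen gives a single number where there was none before, and in this assay the change reads as an at least 2.0-fold lower number from compound 2 to compound 4 (0.30 log units; that floor lies within the scatter). Compound 2 is held only by a limit of the assay, so the full size of this step stays unfixed: the limit of > 20000 nM in this assay, at which 1 of the 4 values shown sits.

The compounds shown leave open whether the amine on the ring matters, as a plain phenyl would show, and whether a carboxylic acid in its place would give a different number.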